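Compound 3 to compound 4: one aromatic substituent exchanged

This account rests on a few compounds, and the source may have more. Where it says the series, first, only, none or still open, it means among the compounds named here.

In a functional assay on DU-145 cells (Homo sapiens) for antiproliferative activity, read by propidium iodide staining, with a stated time of 96 h (on this read-out higher numbers stand for weaker inhibition and lower numbers for stronger inhibition), compound 1 `CC(O)(CSc1ccc(S(F)(F)(F)(F)F)cc1)C(=O)Nc1ccc([N+](=O)[O-])cc1C(F)(F)F` gives 14500 nM and compound 2 `CC(O)(CSc1cccc(OC(F)(F)F)c1)C(=O)Nc1ccc(S(F)(F)(F)(F)F)cc1` gives 23800 nM while compound 3 `CC(O)(CSc1ccc(S(F)(F)(F)(F)F)cc1)C(=O)Nc1cccc(S(F)(F)(F)(F)F)c1` gives 24800 nM and so stands within the scatter of both. Compound 4 `CC(O)(CSc1ccc(OC(F)(F)F)cc1)C(=O)Nc1cccc(S(F)(F)(F)(F)F)c1` has not been measured. It departs from compound 3 by a group of 5 heavy atoms (1 carbon, 1 oxygen, 3 fluorine; no ring) in place of a group of 6 heavy atoms (5 fluorine, 1 sulfur; no ring), on an aromatic carbon with trifluoromethoxy entering para to a large group. Among the compounds with values here, no measured pair differing in one place is available to size this exchange. Compound 2 also carries trifluoromethoxy and gives 23800 nM within the scatter of compound 3. In this assay no change beyond the scatter is therefore expected, in either direction. The estimated value for compound 4 is 20000 nM with an expected range from 9000 nM to 40000 nM on this evidence.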

Compound 4, half-maximal inhibitory concentration: 24700 nM
Beside the measured number, compound 4's estimate is 1.2-fold (0.09 log units) below it; the range from low to high includes it.
By their numbers in this assay, from the lowest: compounds 1, 2, 4 and 3 (each within the scatter of the next).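

In this assay, trifluoromethoxy replaces the group of 6 heavy atoms (5 fluorine, 1 sulfur) on the aromatic carbon para to a large group, giving a 1.0-fold lower number from compound 3 to compound 4 (0.00 log units; within the scatter) and no change beyond the scatter. This is the only pair shown that differs in one place, and so the only direct reading of an exchange at this position. No supporting measurement bears on the result.

Going by these compounds, whether an amine or a carboxylic acid on this carbon would leave the number within the scatter remains open. Also open, on these data alone, is whether the same exchange would give a similar step on the core of compound 1.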